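Ethoxy to Isobutoxy: What Compound 3 Might Show

The source may hold more compounds than are shown below. What is called first, only, known or untested is meant among the compounds shown, and "the series" means these compounds.

Two measured compounds frame this account. Compound 1 `O=C1CC(c2ccccc2OCc2ccc(F)cc2)Oc2ccccc21` in a functional assay on RAW264.7 cells (Mus musculus) for inhibition, read by Griess assay, with stated times of 1 h and 24 h (a lower number here means a stronger inhibitor, a higher number a weaker inhibitor), gives 28200 nM. Compound 2 `CCOc1ccccc1C1CC(=O)c2ccccc2O1` in this assay gives 38500 nM, the higher of the two numbers, yet the step of a 1.4-fold higher number from compound 1 to compound 2 (0.14 log units; within the scatter) lies within the scatter, so the two compounds cannot be ranked against each other. The unmeasured compound 3 `CC(C)COc1ccccc1C1CC(=O)c2ccccc2O1` differs from compound 2 by isopropyl in place of methyl on a saturated chain carbon bound to an oxygen on an aromatic ring. Within the data shown here, the only measured step at this place is a 1.4-fold higher number from compound 1 to compound 2 (0.14 log units; within the scatter), where methyl took the place of 4-fluorophenyl without moving the number beyond the scatter; a far larger group was removed there without effect, and nothing measured speaks directly to isopropyl at this place. On that basis one expects no step beyond the scatter from compound 2 to compound 3 in this assay, written as no change at the digits printed from compound 2 to compound 3 (within the scatter). Compound 3 is accordingly estimated at 38500 nM, with an expected range from 15000 nM to 100000 nM, the range kept wide because a single step, a 1.4-fold higher number from compound 1 to compound 2 (0.14 log units; within the scatter), is thin evidence.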

Compound 3, half-maximal inhibitory concentration: 36700 nM
Compound 3: the middle estimate sits 1.0-fold (0.02 log units) above what was measured, and the stated range covers the measured number.
By their numbers in this assay, from the lowest: compounds 1, 3 and 2 (each within the scatter of the next).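

In this assay, the place on a saturated chain carbon bound to an oxygen on an aromatic ring now has a branched chain group as well, and isopropyl in place of methyl gives a 1.0-fold lower number from compound 2 to compound 3 (0.02 log units; within the scatter) without separating the two compounds. Isopropyl in place of 4-fluorophenyl gives a 1.3-fold higher number from compound 1 to compound 3 (0.11 log units; within the scatter) in the same assay, so methyl, isopropyl and 4-fluorophenyl all lie within the scatter of one another here, whereas the earlier compounds offered only a single comparison, between an aromatic group and methyl. No measurement at hand accounts for this lack of separation among the three groups.

From the compounds shown here alone, whether an amine or a carboxylic acid at the end of the chain, or a much longer chain such as octyl, would move the number beyond the scatter in this assay remains open. Also open, going by these compounds, is what a change to the shared core would do, as compound 1, compound 2 and compound 3 all carry that core unaltered, and the three compounds together show only how little these particular groups separate at this one place.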